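The source may report more compounds than this note shows. Statements on the series, on what has been measured and on what is new or still open speak of the compounds shown alone.

Compound 1 `O=C1/C(=C\c2ccc(F)cc2)c2ccccc2N1c1c(Cl)cccc1Cl` and compound 2 `O=C1/C(=C\c2ccc(Cl)cc2)c2ccccc2N1c1c(Cl)cccc1Cl` share one core and differ only in the aromatic ring attached to the double-bonded chain carbon. In a functional assay on MIA PaCa-2 cells (Homo sapiens) for cytotoxicity, read by MTT assay, with a stated time of 72 h (a lower number here means that less compound is needed, a higher number that more compound is needed for the effect), compound 1 gives 5 ug/mL, and in the same test compound 2 gives 5 ug/mL. The step of no change at the digits printed from compound 1 to compound 2 (within the scatter) lies within the scatter, so compound 2 stands level with compound 1 at the digits shown, and neither can be called the more potent of the two.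

Compound 3 `O=C1/C(=C\c2ccccc2[N+](=O)[O-])c2ccccc2N1c1c(Cl)cccc1Cl` differs from compound 2 by 2-nitrophenyl in place of 4-chlorophenyl on a double-bonded chain carbon bound to a double-bonded ring carbon. Within the data shown here, the only measured step that touches this part of the molecule is the one from compound 1 to compound 2, and it was flat. Among the measured compounds shown here, that step swapped one halogen for another at the same aromatic carbon; the change to compound 3 is broader, since a 2-nitrophenyl takes the place of the 4-chlorophenyl, and no measured pair covers such a ring. With only a flat step to lean on, no shift beyond the scatter is expected. Compound 3 is therefore estimated at 5 ug/mL, with a range from 2.5 ug/mL to 10 ug/mL. The implied step no change at the digits printed from compound 2 to compound 3 (within the scatter) is expected to stay within the usual scatter.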

Compound 3, concentration for half-maximal effect: 5 ug/mL
Estimate against measurement, compound 3: no gap at the digits printed; the range from low to high includes it.
By their numbers in this assay, from the lowest: compounds 1, 2 and 3 (each within the scatter of the next).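

In this assay the 2-nitrophenyl in place of 4-chlorophenyl on a double-bonded chain carbon bound to a double-bonded ring carbon gives no change at the digits printed from compound 2 to compound 3 (within the scatter) and the same group in place of 4-fluorophenyl gives no change at the digits printed from compound 1 to compound 3 (within the scatter) as well. The earlier pair had exchanged only one halogen for another on the same aromatic carbon, whereas these steps replace the whole halogen-bearing phenyl with a nitro-bearing one, bringing in hydrogen-bond acceptors where the leaving groups have none, and the read-out of the three compounds still stays within the scatter. Nothing at hand offers an explanation for this level read-out.

The compounds shown carry only halogen-bearing and nitro-bearing phenyl groups at this place, so the outcome with an unsubstituted phenyl, an amine, a carboxylic acid or a longer chain there remains open. From the compounds shown here alone, whether any group at this place can move the value beyond the scatter also stays open, as does the effect of altering the rest of the shared core.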